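From sulfanyl to sulfonyl on a growth-inhibiting compound

The source may hold more compounds than are shown below. What is called first, only, known or untested is meant among the compounds shown, and "the series" means these compounds.

In a functional assay on DU-145 cells (Homo sapiens) for inhibition, read by trypan blue exclusion, with a stated time of 96 h (a higher number here means a weaker inhibitor of growth, a lower number a stronger inhibitor of growth), compound 1 `O=C(/C(=C\c1ccccc1OCc1ccccc1)SCc1ccc(F)cc1)c1ccc(Cl)cc1` gives 1000 nM. This is the lower of the two numbers available, and the gap to compound 2 `COc1ccc(/C=C(\C(=O)c2ccc(Br)cc2)S(=O)(=O)c2ccc(Br)cc2)c(F)c1`, at 10000 nM, lies beyond the scatter. Compound 3 `O=C(/C(=C\c1ccccc1OCc1ccccc1)S(=O)(=O)Cc1ccc(F)cc1)c1ccc(Cl)cc1` has (4-fluorobenzyl)sulfonyl in place of (4-fluorobenzyl)sulfanyl on a double-bonded chain carbon bound to a carbonyl carbon and a double-bonded chain carbon. Within the data shown here, no measured pair shows this exchange alone. Compound 2 also carries a sulfonyl group and gives 10000 nM, but it differs from compound 1 in several other places, so it is only a faint guide. In this assay, the expected change is a modest rise, meaning a somewhat weaker inhibitor, with the estimated step of a 2.0-fold higher number from compound 1 to compound 3 (0.30 log units; within the scatter) close to the scatter. The estimate for compound 3 is 2000 nM, with an expected range from 300 nM to 10000 nM.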

Compound 3, concentration for 50% growth inhibition: 10000 nM
The estimate for compound 3 lay 5.0-fold (0.70 log units) below the measured number, and the stated range covers the measured number.
By their numbers in this assay, from the lowest: compound 1; then compounds 2 and 3 (each within the scatter of the next).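

Among these compounds, on the double-bonded chain carbon bound to a carbonyl carbon and a double-bonded chain carbon, this pair gives the first clean reading of the exchange: in this assay, (4-fluorobenzyl)sulfonyl in place of (4-fluorobenzyl)sulfanyl gives a 10-fold higher number from compound 1 to compound 3 (1.00 log units; beyond the scatter). Since the rest of the molecule stays the same, this place is sensitive to the change, and the sulfanyl form is the stronger inhibitor of growth in this pair. Nothing available explains this step.

From the compounds shown here alone, how a sulfinyl group or an amine would behave at this place remains open, so one pair cannot show whether the effect rises steadily with the oxygens on sulfur. Going by these compounds, whether the same exchange would give a similar step on a core carrying other groups also remains open.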